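This account rests on a few compounds, and the source may have more. Where it says the series, first, only, none or still open, it means among the compounds named here.

Measured so far:
- compound 1 `O=c1nc2oc(C3CC3)c(C#CC3CC3)c2cn1Cc1cn(Cc2ccccc2)nn1` — 4590 nM
- compound 3 `CCCCCCC#Cc1c(CCCCCC)oc2nc(=O)n(Cc3cn(Cc4ccccc4)nn3)cc12` — 27300 nM
- compound 2 `CCCCCCC#Cc1c(CCCCCC)oc2nc(=O)n(Cc3cn(-c4ccc(Cl)cc4)nn3)cc12` — a limit of the assay, > 100000 nM

All values come from a functional assay on CFPAC-1 cells (Homo sapiens) for antiproliferative activity, read by MTT assay, with a stated time of 72 h; on this read-out higher numbers stand for weaker inhibition and lower numbers for stronger inhibition. Compound 1 gives the lowest number of the two numeric values; compound 3 gives a higher number, but the difference between the two cores is not broken down here, so these two values are only set side by side. Compound 2 does not give a number at all; it sits at the limit of > 100000 nM in this assay, at which 1 of the 3 values shown sits.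

One change is seen directly: 4-chlorophenyl in place of benzyl on an aromatic nitrogen. It makes an at least 3.6-fold higher number from compound 3 to compound 2 (0.56 log units; beyond the scatter), a step that runs against the limit and therefore cannot be sized more closely.

Compound 4 `O=c1nc2oc(C3CC3)c(C#CC3CC3)c2cn1Cc1cn(-c2ccc(Cl)cc2)nn1` carries the same change on the core of compound 1: 4-chlorophenyl in place of benzyl on an aromatic nitrogen. Among the compounds with values here, the place lines read the same word for word, so this is the same change, though on a core that differs from the one of compound 3 in a way not broken down here. Within the data shown here, only the single earlier pair supports an expectation, and it rests on compound 3 moving to compound 2 by an at least 3.6-fold higher number from compound 3 to compound 2 (0.56 log units; beyond the scatter). Compound 4 is thus expected to move from compound 1 by about a 4.4-fold higher number from compound 1 to compound 4 (0.64 log units; beyond the scatter), a step of the same direction and roughly the same size. On that reading compound 4 is estimated to give 20000 nM, with a likely span from 8000 nM to 60000 nM.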

Compound 4, half-maximal inhibitory concentration: 35400 nM
Beside the measured number, compound 4's estimate is 1.8-fold (0.25 log units) below it; the measured number falls inside the stated range.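

In this assay, 4-chlorophenyl in place of benzyl on an aromatic nitrogen gives a 7.7-fold higher number from compound 1 to compound 4 (0.89 log units; beyond the scatter), so on the core of compound 1 the change again moves toward weaker inhibition, and the direction seen on the earlier pair holds on both cores shown. This supports carrying the direction of the change from one core to the other, but it does not fix the size of the step on the core of compound 3, and two cores say nothing about any further core in the series. Compound 2 gives > 100000 nM, which is a limit of the assay and not a number, and the comparison of the two steps stays open on that account: the same change on two cores in this assay, an at least 3.6-fold higher number (0.56 log units; beyond the scatter) from compound 3 to compound 2 and a 7.7-fold higher number (0.89 log units; beyond the scatter) from compound 1 to compound 4; the limit leaves it open whether they differ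

Left open is whether the step belongs to the chlorine or to the exchange of benzyl for a ring set directly on the aromatic nitrogen, which an unsubstituted phenyl or a 4-chlorobenzyl group in the same place would separate on either core. Also open, on these data alone, is how an amine or a carboxylic acid in place of the chlorine would read in this assay.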